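Dichlorophenyl for Dimethylphenyl: an Efficacy Step Ahead

This account rests on a few compounds, and the source may have more. Where it says the series, first, only, none or still open, it means among the compounds named here.

Three compounds have been measured in a functional assay on HEK293 cells for agonist activity at D(4) dopamine receptor (Homo sapiens), read by FLIPR; a lower number here means a smaller maximal response, a higher number a larger maximal response:
compound 1 `Cc1cc(C)cc(NC(=O)CN2CCC(c3cccc[n+]3[O-])CC2)c1`, which gives 76%;
compound 2 `Cc1cccc(C(=O)NCN2CCC(c3cccc[n+]3[O-])CC2)c1`, which gives 77%;
compound 3 `O=C(CN1CCC(c2cccc[n+]2[O-])CC1)Nc1cccc(OC(F)(F)F)c1`, which gives 51%.

Compound 1 stands second highest of the three. Its nearest neighbour is compound 2, whose number lies within the usual scatter of compound 1, so no order between the two can be drawn. Compound 3 lies furthest away, with a lower number beyond the scatter.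

Compound 4 `O=C(CN1CCC(c2cccc[n+]2[O-])CC1)Nc1cccc(Cl)c1Cl` has not yet been measured. It differs from compound 1 in one place: 2,3-dichlorophenyl in place of 3,5-dimethylphenyl on an amide-type nitrogen. For the measured compounds named here, no pair of measured compounds shows this change, so its size is unknown. The account therefore expects a modest downward step a number 12 percentage points lower from compound 1 to compound 4 (beyond the scatter) in this assay, one that may still fall within the scatter. For compound 4 the estimated maximal response is 64%, expected to lie between 40% and 88%.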

Compound 4, largest response reached (reported as efficacy), in percent of the reference or control that the assay uses: 66%
Estimate against measurement, compound 4: 2 percentage points below; low and high end bracket the measured number.
By their numbers in this assay, from the lowest: compound 3; then compounds 4, 1 and 2 (each within the scatter of the next, the first and the last beyond it).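

In this assay, for the compounds shown here, 2,3-dichlorophenyl in place of 3,5-dimethylphenyl on the amide-type nitrogen gives the first readable step at this position: a number 10 percentage points lower from compound 1 to compound 4 (within the scatter). For this one pair, then, chlorine-bearing and methyl-bearing phenyl groups cannot be put in order by maximal response. Nothing available accounts for this result.

The compounds shown leave open whether a plain phenyl, a 3,5-dichlorophenyl or a pyridyl group at this place would keep the response within the scatter of compound 1. They also leave open whether the same change holds on other cores.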